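The source may report more compounds than this note shows. Statements on the series, on what has been measured and on what is new or still open speak of the compounds shown alone.

Compound 1 `CC(C)CSc1nc(N)nc2c1ncn2/C=C1/CC1(CO)CO` gives in an ADME assay on Akata cells (Homo sapiens) for cytotoxicity, with a stated time of 7 days (on this read-out lower numbers stand for higher toxicity in this test and higher numbers for lower toxicity in this test), only the assay limit > 20000 nM.
Compound 2 `Nc1nc(NCc2ccccc2)c2ncn(/C=C3/CC3(CO)CO)c2n1` gives in this assay only the assay limit > 24000 nM.

Compound 2 thus stands at a limit, not at a number, and so does compound 1; the step that the two limits leave unreadable from compound 1 to compound 2 is therefore of unreadable size, as the limit of > 20000 nM in this assay, at which 1 of the 2 values shown sits, and the limit of > 24000 nM in this assay, at which 1 of the 2 values shown sits, show. Compound 3 `CCCCCOc1nc(N)nc2c1ncn2/C=C1/CC1(CO)CO` differs from compound 2 by pentyloxy in place of benzylamino on an aromatic carbon. Among the measured compounds shown here, no measured step bears readably on this change. With both neighbours at their limits, compound 3 is expected to stay near the limit, estimated at 25000 nM (range 10000 nM to 60000 nM). The expected step that the limit leaves unreadable from compound 2 to compound 3 is none beyond the scatter.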

Compound 3, half-maximal cytotoxic concentration: > 20000 nM
Compound 3: a limit, no number; the forecaster's own chance of this, stated with the estimate: 85%; the middle value is on the limit's open side.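

Among the compounds shown here, no step among compound 1, compound 2 and compound 3 can be read in this assay, since all three give only limits. Left open is where their actual cytotoxic concentrations lie, and whether exchanging these groups on the aromatic carbon changes them.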